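This account rests on a few compounds, and the source may have more. Where it says the series, first, only, none or still open, it means among the compounds named here.

Of the compounds shown here, two of this set have been tested in an assay for activation of interferon regulatory factor 3 (Homo sapiens), read by a luciferase reporter, with a stated time of 20 h; on this read-out lower numbers stand for an effect already at smaller amounts and higher numbers for an effect only at larger amounts of compound. Compound 1 `CCCn1c(NC(=O)c2cc3ccccc3n2C)nc2cc(C(N)=O)cc(OC)c21` carries a 1-methyl-1H-indol-2-yl group on its carbonyl and a shorter side chain on the shared core. In this assay compound 1 gives only a limit, > 100000 nM. Compound 2 `COc1cc(C(N)=O)cc2nc(NC(=O)c3cncn3C)n(CCCNC(=O)OCc3ccccc3)c12` carries a 1-methyl-1H-imidazol-5-yl group on its carbonyl and a longer side chain. In this assay compound 2 likewise reaches only a limit, > 100000 nM. Compound 2 therefore stands at the edge of what the assay reports, as the shown evidence states: the limit of > 100000 nM in this assay, at which 2 of the 2 values shown sit. Compound 3 `COc1cc(C(N)=O)cc2nc(NC(=O)c3cc4ccccc4n3C)n(CCCNC(=O)OCc3ccccc3)c12` keeps the longer chain of compound 2 and changes the ring on the carbonyl: 1-methyl-1H-indol-2-yl in place of 1-methyl-1H-imidazol-5-yl on a carbonyl carbon. For the measured compounds named here, no step between two measured compounds is available, and compound 1 already shows the entering group without a measurable effect. The expected step is a number no higher from compound 2 to compound 3 (the limit leaves the size open), that is, no change beyond the scatter and most likely again a limit. Compound 3 is estimated at 100000 nM with a range from 30000 nM to 300000 nM.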

Compound 3, half-maximal effective concentration: > 100000 nM
Compound 3: a limit, no number; the forecaster's own chance of this, stated with the estimate: 85%; the middle value sits exactly at the limit.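

Compound 3 gives only a limit, as do compound 1 and compound 2, so neither the change from compound 2 to compound 3 nor the change from compound 1 to compound 3 can be read as a step. The compounds shown leave open which structure, if any, gives a measurable effect in this assay.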